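Methoxy added next to the existing methoxy on compound 1

The compounds below may be only part of what the source reports. "The series", "measured", "known", "first", "only" and "open" are said of these compounds alone.

Measured compounds:
compound 1 `COc1ccc(-c2cc(/C=C/C(=O)c3ccc(N)cc3)[nH]n2)cc1`: -70%
compound 2 `COc1cc(-c2cc(/C=C/C(=O)c3ccc(F)c(F)c3)[nH]n2)cc(OC)c1OC`: -24%

In a functional assay on OVCAR-3 cells (Homo sapiens) for cytotoxicity, read by sulforhodamine B assay, with a stated time of 48 h, tested at 10 uM (on this read-out higher numbers stand for a weaker effect at the one concentration tested and lower numbers for a stronger effect), compound 1 gives -70% and compound 2 gives -24%; compound 1 stands lower of the two, and the gap between them lies beyond the scatter. Compound 3 `COc1ccc(-c2cc(/C=C/C(=O)c3ccc(N)cc3)[nH]n2)cc1OC` has not been measured. It differs from compound 1 by methoxy in place of hydrogen on an aromatic carbon. Among the compounds with values here, no pair differing in one place has been measured, so the size of this step is open; a change within the scatter, or a small weakening, is expected. Compound 3 is estimated at -60% (range -90% to -20%), a step of a number 10 percentage points higher from compound 1 to compound 3 (within the scatter).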

Compound 3, a percentage reported as activity, at one concentration (the size of the read-out at that concentration, not a potency): -56%
Compound 3: the middle estimate sits 4 percentage points below what was measured; measured number inside the range.
By their numbers in this assay, from the lowest: compound 1; then compound 3; then compound 2.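

In this assay, within the data shown here, methoxy in place of hydrogen on an aromatic carbon, ortho to a methoxy group, gives a number 14 percentage points higher from compound 1 to compound 3 (beyond the scatter), the first step read at a single place. This is a modest weakening of the effect at the one concentration tested, and compound 3 still gives -56%, so the added methoxy reduces the effect without abolishing it. No measurement at hand bears on the origin of this step. On these data alone, whether ethoxy, hydroxy or fluorine on this carbon would give a step of similar size remains open.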